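Swapping the amide ring on a kinase-inhibitor core

The source may hold more compounds than are shown below. What is called first, only, known or untested is meant among the compounds shown, and "the series" means these compounds.

Measured so far:
compound 1 `CCOc1nc(Nc2ccc(C(=O)NCC(C)(C)O)cc2OC)nc2[nH]ccc12` gives 126 nM in an assay on SH-SY5Y cells for inhibition of Leucine-rich repeat serine/threonine-protein kinase 2 (Homo sapiens), with a stated time of 60 min; on this read-out lower numbers stand for stronger inhibition and higher numbers for weaker inhibition;
compound 2 `CCOc1nc(Nc2ccc(C(=O)N3C[C@@H](C)O[C@@H](C)C3)cc2OC)nc2[nH]ccc12` gives 200 nM in this assay.

Compound 2 holds the higher of the two numbers, yet the step of a 1.6-fold higher number from compound 1 to compound 2 (0.20 log units; within the scatter) is within the scatter, so the two amide groups look alike here. Compound 3 `CCOc1nc(Nc2ccc(C(=O)N3CC4(COC4)C3)cc2OC)nc2[nH]ccc12` differs from compound 2 by a group of 7 heavy atoms (5 carbon, 1 nitrogen, 1 oxygen; 2 four-membered non-aromatic rings with 1 hetero atom each) in place of a group of 8 heavy atoms (6 carbon, 1 nitrogen, 1 oxygen; one six-membered non-aromatic ring with 2 hetero atoms), on a carbonyl carbon. Going by the values given here, only that one amide step bears on this change, and it was small, so no shift beyond the scatter is expected in this assay. Compound 3 is therefore estimated at 200 nM, with a range from 90 nM to 450 nM, meaning an expected step of no change at the digits printed from compound 2 to compound 3 (within the scatter).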

Compound 3, half-maximal inhibitory concentration in the Leucine-rich repeat serine/threonine-protein kinase 2 assay: 158 nM
Estimate against measurement, compound 3: 1.3-fold (0.10 log units) above, within the range that was stated.
By their numbers in the Leucine-rich repeat serine/threonine-protein kinase 2 assay, from the lowest: compounds 1, 3 and 2 (each within the scatter of the next).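

In the Leucine-rich repeat serine/threonine-protein kinase 2 assay compound 3 gives 158 nM, and the group with two four-membered rings reads like both earlier amide groups, with a 1.3-fold lower number from compound 2 to compound 3 (0.10 log units; within the scatter) and a 1.3-fold higher number from compound 1 to compound 3 (0.10 log units; within the scatter), so an open chain and two different ring groups on this carbonyl carbon now all lie within the scatter. In a physicochemical assay for solubility, in simulated intestinal fluid, with a stated time of 4 h (a higher number here means a more soluble compound, a lower number a less soluble compound), compound 2 gives 4.4 ug/mL and compound 3 gives 6.2 ug/mL, and the same change gives a 1.4-fold higher number from compound 2 to compound 3 (0.15 log units; within the scatter), so that read-out does not separate this pair either. Nothing available explains why these groups read alike. Still open, going by these compounds, is whether a piperazine or a longer chain ending in a carboxylic acid would also stay within the scatter in the Leucine-rich repeat serine/threonine-protein kinase 2 assay.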